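This account rests on a few compounds, and the source may have more. Where it says the series, first, only, none or still open, it means among the compounds named here.

Measured compounds:
- compound 1 `Fc1ccc(-c2nn3c(NC4CCCC4)cccc3c2-c2ccoc2)cc1`: "not determined" (no result reported)
- compound 2 `Fc1ccc(-c2nn3c(NC4CCCC4)cccc3c2-c2ccncc2)cc1`: 20000 nM
- compound 3 `Fc1ccc(-c2nn3c(NC4CCCC4)cccc3c2-c2c[nH]c(NC3CCCC3)n2)cc1`: 40000 nM

In an ADME assay on Vero cells (Chlorocebus sabaeus) for cytotoxicity (on this read-out lower numbers stand for higher toxicity in this test and higher numbers for lower toxicity in this test), compound 1 gives "not determined" (no result reported); no single number was reported for it, so it cannot be placed on this scale. Compound 2 gives 20000 nM in this assay and compound 3 gives 40000 nM. Going by the values given here, the one step that connects two measured compounds, a 2.0-fold higher number from compound 2 to compound 3 (0.30 log units; within the scatter), swaps one five-membered aromatic group for another on the shared core and leaves the read-out essentially unchanged.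

The unmeasured compound 4 `Nc1n[nH]cc1-c1c(-c2ccc(F)cc2)nn2c(NC3CCCC3)cccc12` differs from compound 1 as follows: 3-amino-1H-pyrazol-4-yl in place of furan-3-yl on an aromatic carbon. This is again an exchange of one small aromatic group for another at the same position of the shared core, the kind of change that in a 2.0-fold higher number from compound 2 to compound 3 (0.30 log units; within the scatter) stayed within the scatter. Among the compounds with values here, compound 1 carries no number, so no step to compound 4 can be computed; the expectation rests on the two measured neighbours, compound 2 at 20000 nM and compound 3 at 40000 nM, both of which show low toxicity in this assay.

Compound 4 is therefore expected to land in the same region, estimated at 30000 nM with a range of 10000 nM to 80000 nM.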

Compound 4, half-maximal cytotoxic concentration: 20000 nM
Compound 4: the middle estimate sits 1.5-fold (0.18 log units) above what was measured; measured number inside the range.
By their numbers in this assay, from the lowest: compounds 2, 4 and 3 (each within the scatter of the next).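

The step of a 2.0-fold lower number from compound 3 to compound 4 (0.30 log units; within the scatter) and the step of no change at the digits printed from compound 2 to compound 4 (within the scatter) both stay within the usual scatter of this assay. Three different groups on this aromatic carbon, next to the ring atom that bears a 4-fluorophenyl group, therefore cannot be told apart in this test: pyridin-4-yl, 2-(cyclopentylamino)-1H-imidazol-4-yl and 3-amino-1H-pyrazol-4-yl. Before this result, that rested on a single exchange; it now holds across all three pairs of measured compounds, including a group with 2 hydrogen-bond donors, though the exchange from furan-3-yl cannot be read, since compound 1 has no number. Nothing available explains why these groups read alike.

All the groups shown at this position are aromatic rings containing nitrogen or oxygen, so it remains open whether a carboxylic acid, a simple open-chain amine or a plain phenyl ring would leave this assay just as unmoved. Going by these compounds, the cyclopentylamino group and the 4-fluorophenyl group on the shared core stay the same throughout, so their share in the read-out also remains open.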